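Removing the fluoro from the aryl ring of compound 3

This account rests on a few compounds, and the source may have more. Where it says the series, first, only, none or still open, it means among the compounds named here.

Three analogues sharing one core have been measured in an assay on IM-9 cells for displacement of a labelled ligand from Substance-P receptor (Homo sapiens), read by scintillation counting, with a stated time of 30 min; on this read-out higher numbers stand for weaker inhibition and lower numbers for stronger inhibition. Compound 1 `CC(=O)N1CCC(C(=O)N2CC[C@H](C(=O)N(C)Cc3cc(C(F)(F)F)cc(C(F)(F)F)c3)[C@@H](c3ccc(C)cc3)C2)CC1` gives 0.18 nM. Compound 2 `CC(=O)N1CCC(C(=O)N2CC[C@H](C(=O)N(C)Cc3cc(C(F)(F)F)cc(C(F)(F)F)c3)[C@@H](c3cccc(C)c3)C2)CC1` gives 0.14 nM, and a 1.3-fold lower number from compound 1 to compound 2 (0.11 log units; within the scatter). Compound 3 `CC(=O)N1CCC(C(=O)N2CC[C@H](C(=O)N(C)Cc3cc(C(F)(F)F)cc(C(F)(F)F)c3)[C@@H](c3ccc(F)cc3C)C2)CC1` gives 0.047 nM and is the strongest of the three: a 3.8-fold lower number from compound 1 to compound 3 (0.58 log units; beyond the scatter) and a 3.0-fold lower number from compound 2 to compound 3 (0.47 log units; beyond the scatter).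

Compound 4 `CC(=O)N1CCC(C(=O)N2CC[C@H](C(=O)N(C)Cc3cc(C(F)(F)F)cc(C(F)(F)F)c3)[C@@H](c3ccccc3C)C2)CC1` is not yet measured. It differs from compound 3 by hydrogen in place of fluoro on an aromatic carbon, so the aryl group goes from 4-fluoro-2-methylphenyl to 2-methylphenyl. For the measured compounds named here, no measured step isolates the fluoro: both steps into compound 3 moved the methyl and introduced the fluoro at once, and each was modest. Since a 1.3-fold lower number from compound 1 to compound 2 (0.11 log units; within the scatter) stays within the scatter while a 3.8-fold lower number from compound 1 to compound 3 (0.58 log units; beyond the scatter) and a 3.0-fold lower number from compound 2 to compound 3 (0.47 log units; beyond the scatter) do not, the fluoro appears to carry much of the gain seen in compound 3, and taking it away is expected to hand part of that gain back. Compound 4 is therefore expected to come in at 0.11 nM, with a range of 0.04 nM to 0.3 nM. That estimate means a 2.3-fold higher number from compound 3 to compound 4 (0.37 log units; beyond the scatter), a step expected to be modest and close to the edge of the scatter.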

Compound 4, half-maximal inhibitory concentration: 0.032 nM
Beside the measured number, compound 4's estimate is 3.4-fold (0.54 log units) above it; the whole stated range lies above it.
By their numbers in this assay, from the lowest: compounds 4 and 3 (each within the scatter of the next); then compounds 2 and 1 (each within the scatter of the next).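

For the compounds shown here, with hydrogen in place of fluoro on this aromatic carbon, para to a large group, the fluoro is isolated for the first time, and in this assay the change stays within the scatter (a 1.5-fold lower number from compound 3 to compound 4 (0.17 log units; within the scatter)), so the fluoro is not needed to keep the numbers of this series at their lowest level. The gain instead follows the 2-methylphenyl group among these compounds: replacing 3-methylphenyl gives a 4.4-fold lower number from compound 2 to compound 4 (0.64 log units; beyond the scatter), and replacing 4-methylphenyl gives a 5.6-fold lower number from compound 1 to compound 4 (0.75 log units; beyond the scatter), both beyond the scatter and both modest, while compound 3 keeps the same methyl placement and stays level with compound 4. Nothing available here explains why the methyl placement matters or why the fluoro makes so little difference.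

On these data alone, it remains open whether the methyl group itself is required, since a plain phenyl group or a 2-chlorophenyl or 2-methoxyphenyl group would test this directly. As far as these compounds go, it is equally open whether a chloro or a methoxy group on the aromatic carbon that held the fluoro would be tolerated as well as fluoro and hydrogen are.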